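A few compounds are considered here, and "the series" means these few. Any claim that something is new, unique, unknown or untested is made for them only; others in the source may bear on it.

In an ADME assay on microsomes from liver (Rattus norvegicus) for metabolic stability (a lower number here means that the compound disappears faster, a higher number that the compound lasts longer), three compounds sharing one core have been measured, and none has yet given a number. Compound 1 `Nc1nc(NCCNc2ncc(-c3ncc[nH]3)c(-c3cc(F)c(F)cc3F)n2)ccc1[N+](=O)[O-]` gives > 0.5 h, which is a limit of the assay. Compound 2 `Nc1nc(NCCNc2ncc(-c3ncc[nH]3)c(-c3cc(F)ccc3Cl)n2)ccc1[N+](=O)[O-]` gives > 0.5 h, also a limit. Compound 3 `Nc1nc(NCCNc2ncc(-c3ncc[nH]3)c(-c3ccc(F)cc3Cl)n2)ccc1[N+](=O)[O-]`, which carries 2-chloro-4-fluorophenyl, gives > 0.5 h, again a limit. The series therefore stands at a single mark, (the limit of > 0.5 h in this assay, at which 3 of the 3 values shown sit), and compound 3 cannot be placed relative to its neighbours.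

Compound 4 `Nc1nc(NCCNc2ncc(-c3ncc[nH]3)c(-c3ccc(F)cc3Br)n2)ccc1[N+](=O)[O-]` has bromo in place of chloro on an aromatic carbon, so 2-chloro-4-fluorophenyl becomes 2-bromo-4-fluorophenyl. The nearest evidence is a step that the two limits leave unreadable from compound 1 to compound 3 and a step that the two limits leave unreadable from compound 2 to compound 3, with a step that the two limits leave unreadable from compound 1 to compound 2 alongside them. None of these steps has a readable size, and none exchanges chloro for bromo. The data therefore support no direction for this change, and no step beyond the usual scatter is expected.

The expectation rests on compound 3 at > 0.5 h, a limit shared by all its measured neighbours. The expected change is a step that the limit leaves unreadable from compound 3 to compound 4. For compound 4 the estimated half-life is 0.8 h, with an expected range from 0.5 h to 2 h, and the assay may well report only a limit again.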

Compound 4, half-life: > 0.5 h
Compound 4: no number, only a limit; the forecaster's own chance of this, stated with the estimate: 85%; the middle value lies beyond the limit too.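

In this assay compound 4 gives > 0.5 h, which is a limit of the assay. Its steps to compound 1, compound 2 and compound 3 therefore cannot be read, and the series still stands at a single mark: the limit of > 0.5 h in this assay, at which 4 of the 4 values shown sit. The compounds shown leave open how the half-lives of these four compounds compare, including whether bromo in place of chloro changes the half-life at all.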